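The source may hold more compounds than are shown below. What is called first, only, known or untested is meant among the compounds shown, and "the series" means these compounds.

Compound 1 `CNC(=O)c1cc(Oc2ccc(NS(=O)(=O)c3ccccc3[N+](=O)[O-])cc2)ccn1`, compound 2 `O=[N+]([O-])c1cc(C(F)(F)F)ccc1S(=O)(=O)Nc1ccc(Oc2ccnc3ccccc23)cc1` and compound 3 `O=[N+]([O-])c1cc(C(F)(F)F)ccc1S(=O)(=O)Nc1ccc(Oc2ccnc3c([N+](=O)[O-])cccc23)cc1` were all examined in a functional assay on PLC-PRF-5 cells (Homo sapiens) for inhibition; a higher number here means a weaker inhibitor, a lower number a stronger inhibitor. In this assay compound 1 gives > 40000 nM, which is a limit of the assay and not a number. Compound 2 in this assay likewise reaches only the limit > 40000 nM. For compound 3 this assay again reports only the limit > 40000 nM, so compound 3 stands at the edge of what the assay can report, with nothing measured beyond it. Within the data shown here, the one change among the measured compounds, a step that the two limits leave unreadable from compound 2 to compound 3, cannot be sized, because the limit of > 40000 nM in this assay, at which 3 of the 3 values shown sit, leaves both of its ends unreadable. Compound 4 `O=[N+]([O-])c1cccc2c(Oc3ccc(NS(=O)(=O)c4ccc(C(F)(F)F)cc4Br)cc3)ccnc12` is the next compound for this assay. It differs from compound 3 by bromo in place of nitro on an aromatic carbon. Among the measured compounds shown here, no measured step bears on this change in a readable way, so neither a size nor a direction can be taken from the data. Compound 4 is therefore expected to remain at the limit, and the estimated step is a step that the limit leaves unreadable from compound 3 to compound 4. Compound 4 is estimated at 60000 nM, between 10000 nM and 250000 nM.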

Compound 4, half-maximal inhibitory concentration: > 40000 nM
Compound 4: a limit, no number; the forecaster's own chance of this, stated with the estimate: 85%; the middle value does not contradict the limit.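

No size or direction can be read for the swap of nitro for bromo between compound 3 and compound 4, because both results are limits, not numbers: the limit of > 40000 nM in this assay, at which 4 of the 4 values shown sit.

The compounds shown leave open how strongly any of them inhibits in this assay, and which changes to their structures would alter that.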